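This account rests on a few compounds, and the source may have more. Where it says the series, first, only, none or still open, it means among the compounds named here.

Compound 1 `CC(C)(C)[Si](C)(C)O[C@H]1CCCO[C@@H]1CC=O` is measured in a functional assay on MCF7S cells (Homo sapiens) for inhibition (on this read-out higher numbers stand for weaker inhibition of growth and lower numbers for stronger inhibition of growth), where compound 1 gives 82000 nM. Compound 2 `COC(=O)/C=C/[C@H]1OCCC[C@@H]1O[Si](C)(C)C(C)(C)C` carries a 2-(methoxycarbonyl)ethenyl in place of the formylmethyl on a saturated ring carbon, and in this assay compound 2 gives 80000 nM; the step is a 1.0-fold lower number from compound 1 to compound 2 (0.01 log units; within the scatter). Compound 3 `COC(=O)/C=C\[C@H]1OCCC[C@@H]1O[Si](C)(C)C(C)(C)C` has the same atoms and bonds as compound 2 and differs only in the configuration as drawn, the double bond being drawn E in compound 2 and Z in compound 3; in this assay compound 3 gives 82000 nM. From compound 1 the step is no change at the digits printed from compound 1 to compound 3 (within the scatter), and from compound 2 it is a 1.0-fold higher number from compound 2 to compound 3 (0.01 log units; within the scatter), a step that rests on (the fact that compounds 2 and 3 differ only in the configuration as drawn). Compound 3 thus stands level with compound 1 at the digits shown, and all three numbers lie within the scatter of one another.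

Compound 4 `CC(C)(C)[Si](C)(C)O[C@H]1CCCO[C@@H]1/C=C\CO` differs from compound 3 by hydroxymethyl in place of methoxycarbonyl on a double-bonded chain carbon bound to a double-bonded chain carbon. For the measured compounds named here, no measured step covers this exchange; the steps that altered the chain on the saturated ring carbon, a 1.0-fold lower number from compound 1 to compound 2 (0.01 log units; within the scatter) and no change at the digits printed from compound 1 to compound 3 (within the scatter), and the geometry step a 1.0-fold higher number from compound 2 to compound 3 (0.01 log units; within the scatter) all stayed within the scatter. Compound 4 is therefore expected to show no step beyond the scatter, a 1.0-fold lower number from compound 3 to compound 4 (0.01 log units; within the scatter), in this assay. The estimate for compound 4 is 80000 nM, with a range from 40000 nM to 160000 nM.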

Compound 4, concentration for total growth inhibition: 23000 nM
Beside the measured number, compound 4's estimate is 3.5-fold (0.54 log units) above it, and the stated range ends above it.
By their numbers in this assay, from the lowest: compound 4; then compounds 2, 1 and 3 (each within the scatter of the next).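

In this assay, for the compounds shown here, the exchange of methoxycarbonyl for hydroxymethyl on a double-bonded chain carbon bound to a double-bonded chain carbon is the first change in this set to go beyond the scatter, with a 3.6-fold lower number from compound 3 to compound 4 (0.55 log units; beyond the scatter). The comparisons with the other two compounds agree, with a 3.5-fold lower number from compound 2 to compound 4 (0.54 log units; beyond the scatter) and a 3.6-fold lower number from compound 1 to compound 4 (0.55 log units; beyond the scatter), so compound 4 is the most potent of the four on this read-out and the end group of this chain matters here in a way that the earlier changes to the chain did not reveal. Nothing on hand bears on why the hydroxymethyl gives the lower number.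

The compounds shown leave open whether the gain is specific to hydroxymethyl, since they do not tell how an aminomethyl, a methoxymethyl or a carboxylic acid at this place would read. They also do not tell whether 3-hydroxyprop-1-en-1-yl drawn E would match compound 4, or whether the gain would survive a longer chain carrying the same terminal hydroxyl.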